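The source may report more compounds than this note shows. Statements on the series, on what has been measured and on what is new or still open speak of the compounds shown alone.

Measured compounds:
- compound 1 `Cc1nnc2nnc(N3CCCC3)nn12`: in a functional assay on BeWo cells (Homo sapiens) for cytotoxicity, read by MTT assay, with a stated time of 72 h (a lower number here means a stronger inhibitor, a higher number a weaker inhibitor), compound 1 gives 5360 nM
- compound 2 `C1CCC(c2nnc3nnc(N4CCCC4)nn23)CC1`: in this assay compound 2 gives 22000 nM
- compound 3 `O=[N+]([O-])c1ccc(-c2nnc3nnc(N4CCCC4)n3n2)cc1`: in this assay compound 3 reaches only a limit of the assay, > 100000 nM

Among the two numbers available, compound 1 stands lowest, and compound 2 is its nearest neighbour, separated by the step of a 4.1-fold higher number from compound 1 to compound 2 (0.61 log units; beyond the scatter). Compound 3 gives no number at all but only a limit (the limit of > 100000 nM in this assay, at which 1 of the 3 values shown sits).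

The compound still to be measured is compound 4 `CC(C)c1nnc2nnc(N3CCCC3)nn12`. It differs from compound 1 in one place: isopropyl in place of methyl on an aromatic carbon. Among the measured compounds shown here, the only measured step that bears on this change is a 4.1-fold higher number from compound 1 to compound 2 (0.61 log units; beyond the scatter), in which a far larger cyclohexyl took the same position and the number rose modestly. Isopropyl adds fewer carbons than cyclohexyl and carries no ring, so a smaller rise in this assay is expected, one that may or may not clear the scatter. Compound 4 is therefore estimated at 9000 nM, with a range from 4000 nM to 25000 nM. The step this estimate implies, a 1.7-fold higher number from compound 1 to compound 4 (0.23 log units; within the scatter), is expected to be smaller than the one seen with cyclohexyl.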

Compound 4, half-maximal inhibitory concentration: 3430 nM
For compound 4 the middle estimate is 2.6-fold (0.42 log units) above the measured one; measured number outside the range, below it.
By their numbers in this assay, from the lowest: compounds 4 and 1 (each within the scatter of the next); then compound 2. At a limit, above all of these: compound 3.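

In this assay, the change from methyl to isopropyl on the aromatic carbon between two ring nitrogen atoms leaves the number within the scatter, with a 1.6-fold lower number from compound 1 to compound 4 (0.19 log units; within the scatter). The earlier compounds had shown only that cyclohexyl at this place gave a higher number than methyl; the new comparison, a 6.4-fold lower number from compound 2 to compound 4 (0.81 log units; beyond the scatter), shows that the same holds against isopropyl, so adding carbons to this position does not by itself move the number. Nothing shown here accounts for these differences.

As far as these compounds go, it remains open whether the ring of cyclohexyl or its carbon count sets it apart from methyl and isopropyl. The compounds shown also leave open how a longer chain such as n-butyl, an amine or a carboxylic acid at this position would read.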